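Shortening the thioamide chain: gastric dose across two cores

The source may hold more compounds than are shown below. What is called first, only, known or untested is meant among the compounds shown, and "the series" means these compounds.

Compound 1 `Cc1ccc(=O)n(CCCCC(=N)S)n1` and compound 2 `Cc1ccc(=O)n(CCC(=N)S)n1` share one core; compound 3 `N=C(S)CCCCCN1N=C(c2ccccc2)CCC1=O` and compound 4 `N=C(S)CCCN1N=C(c2ccccc2)CCC1=O` share another, and the difference between the two cores is not broken down here. In a functional assay on the whole organism (stomach) with Rattus norvegicus as the target (on this read-out lower numbers stand for an effect already at smaller amounts and higher numbers for an effect only at larger amounts of compound), compound 1 reaches only a limit of the assay, > 100 mg/kg. In this assay compound 2 gives 43.2 mg/kg. The change between them is a group of 3 heavy atoms (1 carbon, 1 nitrogen, 1 sulfur; no ring) in place of a group of 5 heavy atoms (3 carbon, 1 nitrogen, 1 sulfur; no ring), on a saturated chain carbon, two bonds along the chain from an aromatic nitrogen. It produces an at least 2.3-fold lower number from compound 1 to compound 2 (0.36 log units; beyond the scatter); the size of that step is bounded from one side only because of the limit of > 100 mg/kg in this assay, at which 1 of the 3 values shown sits. In this assay compound 3 gives 100 mg/kg, and compound 2 is the nearest measured number to it. Compound 4 carries the same kind of change on the other core: a group of 3 heavy atoms (1 carbon, 1 nitrogen, 1 sulfur; no ring) in place of a group of 5 heavy atoms (3 carbon, 1 nitrogen, 1 sulfur; no ring), on a saturated chain carbon, three bonds along the chain from an amide-type nitrogen in a ring. The place is not identical, three bonds along the chain from an amide-type nitrogen in a ring rather than two bonds along the chain from an aromatic nitrogen. Compound 4 is expected to give 45 mg/kg, estimated between 20 mg/kg and 100 mg/kg. The expected step is a 2.2-fold lower number from compound 3 to compound 4 (0.35 log units; beyond the scatter), which rests on the lowering measured as an at least 2.3-fold lower number from compound 1 to compound 2 (0.36 log units; beyond the scatter) and on the starting point of compound 3 at 100 mg/kg.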

Compound 4, dose for half-maximal effect: 100 mg/kg
Compound 4: middle estimate off by 2.2-fold (0.35 log units), on the low side; measured number inside the range.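

In this assay, shortening the chain on the core of compound 3 gives no change at the digits printed from compound 3 to compound 4 (within the scatter), so the lowering seen on the other core does not reappear as a measured step here. Set side by side, the two pairs read as follows: the same change on two cores in this assay, an at least 2.3-fold lower number (0.36 log units; beyond the scatter) from compound 1 to compound 2 and no change at the digits printed (within the scatter) from compound 3 to compound 4; the limit leaves it open whether they differ The pair on the second core therefore gives no support for carrying the change over as a reliable lowering in this series, but it does not show that the effect of the change depends on the core, and the true size of the first step stays unknown: the limit of > 100 mg/kg in this assay, at which 1 of the 4 values shown sits.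

Two pairs cannot separate the core from the place of the change, which is three bonds along the chain from an amide-type nitrogen in a ring on one core and two bonds along the chain from an aromatic nitrogen on the other. Also open, as far as these compounds go, is how a longer chain, or an amine or a carboxylic acid at the chain end, would read in this assay on either core.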